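This account rests on a few compounds, and the source may have more. Where it says the series, first, only, none or still open, it means among the compounds named here.

The measured compounds in a functional assay on isolated protein for inhibition of Glucose-dependent insulinotropic receptor (Rattus norvegicus), read by HTRF and cAMP accumulation (on this read-out lower numbers stand for an effect already at smaller amounts and higher numbers for an effect only at larger amounts of compound), are:
compound 1, `Cc1nc(S(C)(=O)=O)ccc1Oc1ncnc(OC2CCN(C(=O)OC(C)F)CC2)c1F`, giving 315 nM
compound 2, `Cc1nc(S(C)(=O)=O)ccc1Oc1ncnc(OC2CCN(C(=O)O[C@H](C)CF)CC2)c1F`, giving 1520 nM
compound 3, `Cc1nc(S(C)(=O)=O)ccc1Oc1ncnc(OC2CCN(C(=O)O[C@H](C)C(F)(F)F)CC2)c1F`, giving 110 nM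

Compound 2 stands at the highest number of the three in this assay. The nearest to it is compound 1, with a 4.8-fold higher number from compound 1 to compound 2 (0.68 log units; beyond the scatter) separating them, and the furthest is compound 3, with a 14-fold lower number from compound 2 to compound 3 (1.14 log units; beyond the scatter); between the other two there is a 2.9-fold lower number from compound 1 to compound 3 (0.46 log units; beyond the scatter). All three steps vary only the fluorine pattern on the chain carbon bound to the oxygen of the carbamate, and all three lie beyond the scatter, so this part of the molecule is one where changes register clearly.

Compound 4, `Cc1nc(S(C)(=O)=O)ccc1Oc1ncnc(OC2CCN(C(=O)SC3CCC3)CC2)c1F`, differs from compound 2 by a group of 5 heavy atoms (4 carbon, 1 sulfur; one four-membered non-aromatic ring of carbon only) in place of a group of 5 heavy atoms (3 carbon, 1 oxygen, 1 fluorine; no ring), on a carbonyl carbon. For the measured compounds named here, none of the measured steps exchanges the oxygen for a sulfur or introduces a ring at this place, so they bear on the change only indirectly: they show the position is sensitive, not which way a sulfur-linked ring will move the number. Because compound 2 gives 1520 nM and both of its neighbours sit lower, a move downward is the more likely outcome, but with wide uncertainty. Compound 4 is therefore expected at 400 nM, between 100 nM and 1600 nM. This estimate means an expected 3.8-fold lower number from compound 2 to compound 4 (0.58 log units; beyond the scatter).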

Compound 4, half-maximal effective concentration: 77.4 nM
The estimate for compound 4 lay 5.2-fold (0.71 log units) above the measured number, outside the stated range (below it).
By their numbers in this assay, from the lowest: compounds 4 and 3 (each within the scatter of the next); then compound 1; then compound 2.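

In this assay the exchange on the carbonyl carbon, with cyclobutylsulfanyl entering, gives a 20-fold lower number from compound 2 to compound 4 (1.29 log units; beyond the scatter) and also a 4.1-fold lower number from compound 1 to compound 4 (0.61 log units; beyond the scatter) so this place accepts a sulfur-linked ring of carbon and not only oxygen-linked chains. The remaining step, a 1.4-fold lower number from compound 3 to compound 4 (0.15 log units; within the scatter) is within the scatter, which places the fluorine-free compound 4 level with compound 3 and shows that a trifluoromethyl group is not the only route to the low numbers seen in this series. No measurement in hand explains why the cyclobutylsulfanyl group behaves in this way.

What the compounds shown leave open is whether the sulfur or the ring accounts for the step, since both enter together and no pair isolates either one. Cyclobutoxy on the same carbonyl carbon would isolate the linking atom, 1-(trifluoromethyl)ethylsulfanyl would test sulfur with the fluorinated chain kept, and cyclopentylsulfanyl would show whether ring size matters at this place.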